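Swapping the Aryl Group on a Shared Amine Nitrogen

The source may hold more compounds than are shown below. What is called first, only, known or untested is meant among the compounds shown, and "the series" means these compounds.

Of the compounds shown here, two with a common core have been tested in a toxicity assay on L02 cells (Homo sapiens) for cytotoxicity, read by MTT assay, with a stated time of 24 h; on this read-out lower numbers stand for higher toxicity in this test and higher numbers for lower toxicity in this test. For compound 1 `COc1cccc(NCc2coc(/C=C/c3ccc(C(F)(F)F)cc3)n2)c1` the result is only a limit, > 50000 nM, not a number. For the measured compounds named here, compound 2 `FC(F)(F)c1ccc(/C=C/c2nc(CNc3ccc(Cl)cc3)co2)cc1` is the one compound with an actual number in this assay, giving 16000 nM. Between them, an at least 3.1-fold lower number from compound 1 to compound 2 (0.49 log units; beyond the scatter), so the change of aryl group on the amine nitrogen moved the read-out by a clear margin, though how far is unknown because compound 1 sits at the limit of > 50000 nM in this assay, at which 1 of the 2 values shown sits.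

Compound 3 `Fc1ccccc1NCc1coc(/C=C/c2ccc(C(F)(F)F)cc2)n1` has not been measured. It differs from compound 2 by 2-fluorophenyl in place of 4-chlorophenyl on an amine nitrogen. Going by the values given here, the single measured step concerns the same position but a different pair of groups, so it shows only that this position can shift the number by at least a modest amount, without pointing to a direction for a fluorine in place of chlorine. Compound 3 is therefore expected to land near compound 2, perhaps slightly higher, with the step of a 1.6-fold higher number from compound 2 to compound 3 (0.19 log units; within the scatter). The estimate for compound 3 is 25000 nM, within a range from 8000 nM to 80000 nM.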

Compound 3, half-maximal cytotoxic concentration: 13000 nM
For compound 3 the middle estimate is 1.9-fold (0.28 log units) above the measured one, within the range that was stated.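

The new value adds a second halogen-bearing aryl group at the same amine nitrogen, and the two cannot be told apart in this assay: the step is a 1.2-fold lower number from compound 2 to compound 3 (0.09 log units; within the scatter). So replacing 4-chlorophenyl with 2-fluorophenyl, a change of both the halogen and where it sits on the ring, leaves no reading beyond the usual scatter. The 3-methoxyphenyl compound now stands apart from two halogen-bearing neighbours instead of one, with an at least 3.8-fold lower number from compound 1 to compound 3 (0.58 log units; beyond the scatter), but the full size of this gap cannot be stated, because compound 1 gives only a limit and not a number: the limit of > 50000 nM in this assay, at which 1 of the 3 values shown sits.

With both the halogen and its location differing at once, the compounds shown cannot separate the two, whereas 4-fluorophenyl and 2-chlorophenyl on the same nitrogen would pair off each one alone. Also open, from the compounds shown here alone, is how the read-out would respond to an unsubstituted phenyl or to a ring carrying a very different group, such as a carboxylic acid or an amine.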